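The source may report more compounds than this note shows. Statements on the series, on what has been measured and on what is new or still open speak of the compounds shown alone.

Of the three compounds measured in an ADME assay on the whole organism (Mus musculus, strain ICR) for metabolic stability, at a dose of 50 mg/kg by the oral route (a higher number here means that the compound lasts longer, a lower number that the compound disappears faster), compound 2 `N#CC1CC(=O)N(c2cnn3c2CN(C(=O)Nc2cc(F)c(F)c(F)c2)C(C2CC2)C3)C1` stands highest at 4.63 h, ahead of compound 3 `C[C@H]1Cn2ncc(N3CC(c4ccccc4)CC3=O)c2CN1C(=O)Nc1cc(F)c(F)c(F)c1` at 2.27 h and compound 1 `O=C1CC(Oc2ncccn2)CN1c1cnn2c1CN(C(=O)Nc1cc(F)c(F)c(F)c1)C(C1CC1)C2` at 0.95 h; both gaps lie beyond the scatter. The next structure, compound 4 `O=C1CC(c2ncccn2)CN1c1cnn2c1CN(C(=O)Nc1cc(F)c(F)c(F)c1)C(C1CC1)C2`, carries pyrimidin-2-yl in place of cyano on a saturated ring carbon.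

Among the compounds with values here, one measured step bears on this change: a 4.9-fold higher number from compound 1 to compound 2 (0.69 log units; beyond the scatter), a modest step with cyano replacing (pyrimidin-2-yl)oxy on that same carbon. It is only an indirect guide, as the group leaving here is cyano but the group entering is pyrimidin-2-yl, not the (pyrimidin-2-yl)oxy of compound 1. Compound 3 also differs from compound 2 elsewhere in the structure, so it gives no clean comparison. A modest fall in this assay is therefore expected, probably smaller than the measured step. The expected change is a 2.6-fold lower number from compound 2 to compound 4 (0.41 log units; beyond the scatter). For compound 4, the estimated half-life is 1.8 h, with an expected range of 0.8 h to 4 h.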

Compound 4, half-life: 0.87 h
For compound 4 the middle estimate is 2.1-fold (0.32 log units) above the measured one; the range from low to high includes it.
By their numbers in this assay, from the lowest: compounds 4 and 1 (each within the scatter of the next); then compound 3; then compound 2.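

In this assay, moving from the nitrile to the six-membered aromatic ring on this saturated ring carbon gives a 5.3-fold lower number from compound 2 to compound 4 (0.73 log units; beyond the scatter) and brings the half-life back to the level of the (pyrimidin-2-yl)oxy compound. The two pyrimidine-bearing groups are not separated, with a 1.1-fold lower number from compound 1 to compound 4 (0.04 log units; within the scatter) as the printed step, so the oxygen link makes no difference that can be read in this pair. Among compounds 1, 2 and 4, which differ only at this carbon, the high half-life therefore belongs to the cyano compound alone, and compound 3 differs elsewhere and does not enter this reading. No data in hand bear on the origin of these differences.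

Going by these compounds, it remains open whether a methyl, hydroxyl or carboxylic acid on this carbon would stand with compound 2 or with compounds 1 and 4. A plain phenyl on the same core would show whether the pyrimidine nitrogens matter here.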